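The source may report more compounds than this note shows. Statements on the series, on what has been measured and on what is new or still open speak of the compounds shown alone.

Series notes, thiazole acetic acids at the prostaglandin D2 receptor 2.

In an in vitro functional assay on HEK285-7 cells for antagonist activity at prostaglandin D2 receptor 2 (Homo sapiens), read by BRET and beta-arrestin recruitment (a higher number here means a weaker inhibitor, a lower number a stronger inhibitor), compound 2 `O=C(O)Cc1sc(C(c2ccc(F)cc2)c2ccc(F)cc2)nc1-c1ccco1` gives 140 nM. This is the lowest of the two numbers in hand. Compound 1 `Cc1nc(-c2ccc(Cl)cc2)c(CC(=O)O)s1` gives 41000 nM in this assay, which stands far beyond the usual scatter from compound 2. For the measured compounds named here, compound 3 `COc1ccc(OC)c(-c2nc(C(c3ccccc3)c3ccccc3)sc2CC(=O)O)c1` gives only a limit of the assay, > 100000 nM, so no number can be placed for it; it is the one value that sits at the limit of > 100000 nM in this assay, at which 1 of the 3 values shown sits.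

Compound 4 `O=C(O)Cc1sc(C(c2ccc(F)cc2)c2ccc(F)cc2)nc1-c1cn[nH]c1` is not yet measured in this assay. It differs from compound 2 in one place: 1H-pyrazol-4-yl in place of furan-2-yl on an aromatic carbon. Going by the values given here, no step between two measured compounds matches this change, so the direction has to be guessed. The bis(4-fluorophenyl)methyl group that marks compound 2 out from compound 1 is kept in compound 4, so a large loss is not expected; a modest step in either direction is the working assumption. Compound 4 is estimated at 300 nM in this assay, within 60 nM to 1500 nM, which means an expected step of a 2.1-fold higher number from compound 2 to compound 4 (0.33 log units; beyond the scatter).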

Compound 4, half-maximal inhibitory concentration: 220 nM
Compound 4: middle estimate off by 1.4-fold (0.13 log units), on the high side, and the stated range covers the measured number.
By their numbers in this assay, from the lowest: compounds 2 and 4 (each within the scatter of the next); then compound 1. At a limit, above all of these: compound 3.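

At this position, on an aromatic carbon next to the ring nitrogen and next to the ring atom that bears a carboxymethyl group, this assay gives the only step among the compounds shown, and it separates the two rings by no more than the usual scatter: a 1.6-fold higher number from compound 2 to compound 4 (0.20 log units; within the scatter). With the bis(4-fluorophenyl)methyl group kept, furan-2-yl and 1H-pyrazol-4-yl, which adds a hydrogen-bond donor, therefore read alike in this series. Nothing shown bears on why the two rings read alike.

This single step cannot separate the ring nitrogens from the hydrogen-bond donor, and a 1-methyl-1H-pyrazol-4-yl group would be needed to address that. On these data alone, how a plain phenyl ring or an amine would read at this position also remains open.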